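The source may report more compounds than this note shows. Statements on the series, on what has been measured and on what is new or still open speak of the compounds shown alone.

Working notes on the series. Compound 2 `O=C(CCc1cn(C(=O)c2ccccc2)c2ccccc12)N1CCOCC1` is measured in an assay on cells for inhibition of Polyunsaturated fatty acid 5-lipoxygenase (Rattus norvegicus), tested at 5 uM (on this read-out lower numbers stand for less inhibition and higher numbers for more inhibition at the one concentration tested (going by the name of the read-out)), and gives 23.4%. Among the measured compounds shown here, the only other compound with a number, compound 1 `O=C(CCCc1cn(C(=O)c2ccc(Cl)cc2)c2ccccc12)N1CCOCC1`, differs from compound 2 in two places at once, so no single step between them is counted; in this assay compound 1 gives 32.4%, and the two values lie within the usual scatter of each other, so compound 2 cannot be set apart from compound 1 on these numbers.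

Compound 3 `O=C(CCc1cn(C(=O)c2ccc(Cl)cc2)c2ccccc12)N1CCOCC1` has not been measured. It differs from compound 2 in one place: chloro in place of hydrogen on an aromatic carbon. For the measured compounds named here, no measured pair shows this change on its own. Going by the values given here, the only hint is that compound 1, which carries the same chloro, sits at 32.4%, not far from compound 2. The step from compound 2 to compound 3 is therefore expected to be small, a number 4.6 percentage points higher from compound 2 to compound 3 (within the scatter), possibly nothing beyond the scatter, with the direction uncertain. Compound 3 is expected to give about 28%, between 12% and 45%.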

Compound 3, a percentage reported as inhibition, at one concentration (the size of the read-out at that concentration, not a potency): 26%
Compound 3: the middle estimate sits 2 percentage points above what was measured; the range from low to high includes it.
By their numbers in this assay, from the lowest: compounds 2, 3 and 1 (each within the scatter of the next).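

In this assay, chloro in place of hydrogen on an aromatic carbon, para to a large group, can now be read as a change on its own: a number 2.6 percentage points higher from compound 2 to compound 3 (within the scatter). The change of ((morpholin-4-yl)carbonyl)methyl to (morpholin-4-yl)carbonyl on the saturated chain can also be read alone, a number 6.4 percentage points lower from compound 1 to compound 3 (within the scatter), so neither change sets one compound apart from another on these numbers. Nothing available offers a reason for either step.

Going by these compounds, it remains open whether a different group at the same place on the ring, such as methoxy or a carboxylic acid, would move the read-out beyond the scatter. On these data alone, it is equally open whether a longer chain than that of compound 1, or piperidine in place of morpholine, would do so.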